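One added methyl on a diene chain

A few compounds are considered here, and "the series" means these few. Any claim that something is new, unique, unknown or untested is made for them only; others in the source may bear on it.

Compound 1 `C/C=C(C)\C=C\[C@](C)(O)C/C=C/[C@H]1[C@H](O)CC(=O)[C@@H]1CC/C=C\CCC(=O)OC` gives 0.000016 mg/kg
Compound 2 `C=C/C=C/[C@](C)(O)C/C=C/[C@H]1[C@H](O)CC(=O)[C@@H]1CC/C=C\CCC(=O)OC` gives 0.000007 mg/kg

Both numbers come from a functional assay on the whole organism with Canis familiaris (Canis lupus familiaris) as the target (on this read-out higher numbers stand for an effect only at larger amounts of compound and lower numbers for an effect already at smaller amounts), and, of the two, compound 2 stands lowest (0.000007 mg/kg), so it acts at the smaller dose. Compound 3 `C=C/C(C)=C/[C@](C)(O)C/C=C/[C@H]1[C@H](O)CC(=O)[C@@H]1CC/C=C\CCC(=O)OC` differs from compound 2 in one place (2-methylbuta-1,3-dien-1-yl in place of buta-1,3-dien-1-yl on a saturated chain carbon bound to an oxygen on a saturated carbon and two saturated chain carbons): 2-methylbuta-1,3-dien-1-yl stands in place of buta-1,3-dien-1-yl. Among the measured compounds shown here, only one measured step bears on this (a 2.3-fold lower number from compound 1 to compound 2 (0.36 log units; beyond the scatter)), in which vinyl replaced 1-methylprop-1-en-1-yl. That step was modest but beyond the scatter. The methyl added in compound 3 undoes only part of that structural change, so only part of that step can reasonably be expected to return. A small rise in the number is therefore expected (a 1.4-fold higher number from compound 2 to compound 3 (0.15 log units; within the scatter)), probably no larger than the scatter. The expected value for compound 3 is 0.00001 mg/kg (estimated range 0.000004 mg/kg to 0.00003 mg/kg).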

Compound 3, dose for half-maximal effect: 0.00071 mg/kg
Compound 3: middle estimate off by 71-fold (1.85 log units), on the low side; measured number outside the range, above it.
By their numbers in this assay, from the lowest: compound 2; then compound 1; then compound 3.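

In this assay, one added methyl, turning buta-1,3-dien-1-yl into 2-methylbuta-1,3-dien-1-yl, gives a large change (a 100-fold higher number from compound 2 to compound 3 (2.01 log units; beyond the scatter)), so this part of the chain is far less forgiving than the earlier pair suggested. The methyl-bearing 3-methylpenta-1,3-dien-1-yl group of compound 1 also stands well apart from this new group (a 44-fold higher number from compound 1 to compound 3 (1.65 log units; beyond the scatter)), so among these three compounds, having a methyl on the diene does not by itself decide the result; where it stands in the chain does. No measurement here accounts for the size of this change.

On these data alone, it remains open whether the large rise belongs to methyl alone or would also appear with a fluorine atom or a hydroxymethyl group in its place. A whole-organism dose also leaves open which step between dosing and effect this change alters.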